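Half-life shifts as the benzylamine aryl group changes

The source may report more compounds than this note shows. Statements on the series, on what has been measured and on what is new or still open speak of the compounds shown alone.

Compound 3 `CC(C)(C)CCC1(NCc2ccc3ccccc3c2)C(=O)C(C2=NS(=O)(=O)c3cc(NS(C)(=O)=O)ccc3N2)=C(O)c2ccccc21` stands highest of the three compounds measured in an in vivo ADME assay on the whole organism (strain Sprague-Dawley) for metabolic stability, with Rattus norvegicus as the target, at a dose of 5 mg/kg by the intravenous route (a lower number here means that the compound disappears faster, a higher number that the compound lasts longer), where compound 3 gives 2.2 h. Compound 2 `CON[C@]1(CCC(C)C)C(=O)C(C2=NS(=O)(=O)c3cc(NS(C)(=O)=O)ccc3N2)=C(O)c2ccccc21` gives 0.6 h in this assay, and compound 1 `Cc1ccc(CNC2(CCC(C)(C)C)C(=O)C(C3=NS(=O)(=O)c4cc(NS(C)(=O)=O)ccc4N3)=C(O)c3ccccc32)cn1` gives 0.5 h. Within the data shown here, the one measured step that bears on the present question is a 4.4-fold higher number from compound 1 to compound 3 (0.64 log units; beyond the scatter), a change at the same position. Compound 4 `COc1ccccc1CNC1(CCC(C)(C)C)C(=O)C(C2=NS(=O)(=O)c3cc(NS(C)(=O)=O)ccc3N2)=C(O)c2ccccc21` differs from compound 3 by 2-methoxyphenyl in place of naphthalen-2-yl on a saturated chain carbon bound to an amine nitrogen, which again exchanges the naphthalen-2-yl group for a single six-membered aromatic ring. Given a 4.4-fold higher number from compound 1 to compound 3 (0.64 log units; beyond the scatter), for compound 4 a drop of roughly that size is expected, a 3.1-fold lower number from compound 3 to compound 4 (0.50 log units; beyond the scatter). Compound 4 is therefore estimated at 0.7 h, with a range from 0.3 h to 1.8 h.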

Compound 4, half-life: 3.2 h
The estimate for compound 4 lay 4.6-fold (0.66 log units) below the measured number, outside the stated range (above it).
By their numbers in this assay, from the lowest: compounds 1 and 2 (each within the scatter of the next); then compounds 3 and 4 (each within the scatter of the next).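

In this assay, the change to 2-methoxyphenyl gives a 1.5-fold higher number from compound 3 to compound 4 (0.16 log units; within the scatter) and so shows that a single six-membered aromatic ring at this position does not by itself go with the short half-life of compound 1. Set against 6-methylpyridin-3-yl, the same group gives a 6.4-fold higher number from compound 1 to compound 4 (0.81 log units; beyond the scatter) and thereby separates compound 1 from both compounds with carbon-only aromatic rings. No evidence here accounts for these differences. Going by these compounds, it remains open whether a plain phenyl or a pyridine ring without the methyl would group with compound 1 or compound 4.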